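Compound 3: a step back towards compound 1?

The source may report more compounds than this note shows. Statements on the series, on what has been measured and on what is new or still open speak of the compounds shown alone.

- Compound 1 `O=S(=O)(Nc1ccc(Cl)cc1Cl)c1ccc(-c2cnc(C3CC3)o2)cc1` gives 74500 nM
- Compound 2 `Cc1cc(NS(=O)(=O)c2ccc(-c3cnc(C4CC4)o3)cc2)ccc1Cl` gives 33400 nM
- Compound 3 `O=S(=O)(Nc1ccc(F)cc1F)c1ccc(-c2cnc(C3CC3)o2)cc1` is not yet measured

For the measured compounds named here, in a functional assay on cells (leukaemia cell line, Homo sapiens) for inhibition, read by sulforhodamine B assay, with a stated time of 48 h (a lower number here means a stronger inhibitor of growth, a higher number a weaker inhibitor of growth), compound 2 holds the lower of the two numbers so far. Compound 3 differs from it by 2,4-difluorophenyl in place of 4-chloro-3-methylphenyl on a sulfonamide nitrogen and so has 2,4-difluorophenyl in place of 4-chloro-3-methylphenyl on a sulfonamide nitrogen. Going by the values given here, one measured step bears on this change: a 2.2-fold lower number from compound 1 to compound 2 (0.35 log units; beyond the scatter) is modest and brought in the group that now leaves. Compound 3 carries 2,4-difluorophenyl where compound 1, at 74500 nM, carries 2,4-dichlorophenyl, so a step of similar size towards a higher number is expected. The estimated change is a 2.1-fold higher number from compound 2 to compound 3 (0.32 log units; beyond the scatter) in this assay. For compound 3 the expected value is 70000 nM, within an estimated range of 30000 nM to 100000 nM.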

Compound 3, concentration for total growth inhibition: 66100 nM
Beside the measured number, compound 3's estimate is 1.1-fold (0.02 log units) above it; measured number inside the range.
By their numbers in this assay, from the lowest: compounds 2, 3 and 1 (each within the scatter of the next, the first and the last beyond it).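

In this assay, 2,4-difluorophenyl in place of 2,4-dichlorophenyl on a sulfonamide nitrogen gives a 1.1-fold lower number from compound 1 to compound 3 (0.05 log units; within the scatter), so this exchange of halogens cannot be told from the scatter. Against 4-chloro-3-methylphenyl, 2,4-difluorophenyl gives a 2.0-fold higher number from compound 2 to compound 3 (0.30 log units; within the scatter), so compound 3 is not separated from compound 2 either, although compound 1 and compound 2 are separated. No measurement here accounts for these numbers. The compounds shown leave open how an amine, a carboxylic acid or a longer chain in place of these phenyl groups on a sulfonamide nitrogen would read in this assay.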